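Flipping the Double Bond: From Compound 3 to Compound 4

The compounds below may be only part of what the source reports. "The series", "measured", "known", "first", "only" and "open" are said of these compounds alone.

compound 1 `CCCCCCCCCCCCc1ccccc1C(SCCC(=O)O)SCCC(=O)O` — 445 nM
compound 2 `C#CCCCCCCCCCCc1ccccc1C(SCCC(=O)O)SCCC(=O)O` — 141 nM
compound 3 `CCCCCCCCCC/C=C\c1ccccc1C(SCCC(=O)O)SCCC(=O)O` — 1380 nM

In an assay on membranes from lung (Cavia porcellus) for binding affinity to cysteinyl leukotriene receptor (Homo sapiens) (a higher number here means a weaker inhibitor, a lower number a stronger inhibitor), compound 3 gives the highest of the three numbers, so it is the weakest inhibitor of the set. Compound 1 gives the lower 445 nM, and compound 2 gives the lowest 141 nM, both beyond the scatter from compound 3.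

Compound 4 `CCCCCCCCCC/C=C/c1ccccc1C(SCCC(=O)O)SCCC(=O)O` differs from compound 3 only in this way: the two compounds have the same atoms and bonds and differ only in configuration as drawn: 1 of 1 stereo elements differ; a double bond is drawn Z in compound 3 and E in compound 4. Within the data shown here, the single measured step, a 3.2-fold lower number from compound 1 to compound 2 (0.50 log units; beyond the scatter), concerns the far end of the chain and not the geometry of a double bond, so it offers no guide here. With nothing to lean on, no step beyond the scatter is expected for a 1.2-fold lower number from compound 3 to compound 4 (0.06 log units; within the scatter). Compound 4 is therefore estimated at 1200 nM, within 350 nM to 4000 nM.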

Compound 4, inhibition constant: 491 nM
Beside the measured number, compound 4's estimate is 2.4-fold (0.39 log units) above it; the range from low to high includes it.
By their numbers in this assay, from the lowest: compound 2; then compounds 1 and 4 (each within the scatter of the next); then compound 3.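

Among these compounds, until now, the only measured change sat at the far end of the chain; this one shows that the geometry of the double bond also matters in this assay. Redrawing that double bond from Z to E gives a 2.8-fold lower number from compound 3 to compound 4 (0.45 log units; beyond the scatter). The shift can be assigned to geometry alone, since nothing else changes: the fact that compounds 3 and 4 differ only in the configuration as drawn

An amide in place of this double bond remains an open case. So does a longer chain carrying the same E double bond, where the size of this step could differ.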